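This account rests on a few compounds, and the source may have more. Where it says the series, first, only, none or still open, it means among the compounds named here.

Measured compounds:
- compound 1, `O=C1OC[C@H](Cc2ccccc2)[C@H]1Cc1ccccc1`: 77000 nM
- compound 2, `CCCCOc1cccc(C[C@H]2C(=O)OC[C@@H]2Cc2ccccc2)c1`: 26000 nM

Both numbers come from a functional assay on HL-60 cells (Homo sapiens) for cytotoxicity, read by WST assay, with a stated time of 48 h; a higher number here means that more compound is needed for the effect, a lower number that less compound is needed. Among the measured compounds shown here, compound 2 stands at the lower of the two, and its only neighbour is compound 1, a 3.0-fold lower number from compound 1 to compound 2 (0.47 log units; beyond the scatter) step that was brought about by a butoxy in place of hydrogen on an aromatic carbon. That single step is modest, yet beyond the scatter of the method.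

Compound 3, `CCCCOc1ccc(C[C@H]2C(=O)OC[C@@H]2Cc2ccccc2)cc1OCCCC`, has not yet been measured. It carries one change from compound 2: butoxy in place of hydrogen on an aromatic carbon. For the measured compounds named here, the change is the same kind of replacement, butoxy in place of hydrogen on an aromatic carbon, that separates compound 1 from compound 2, so the step from compound 1 to compound 2 is the only measured step that bears on it. Going by the values given here, on that basis a further modest lowering is expected in this assay, though a second group of the same kind need not repeat the first step in full. For compound 3 the expected step is a 1.7-fold lower number from compound 2 to compound 3 (0.24 log units; within the scatter), and the value is estimated at 15000 nM, within a range of 6000 nM to 40000 nM.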

Compound 3, half-maximal effective concentration: > 100000 nM
Compound 3 was reported as a limit (the forecaster's own chance of this, stated with the estimate: 5%); middle value at least 6.6-fold (0.82 log units) from the limit.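

The same replacement that gave a 3.0-fold lower number from compound 1 to compound 2 (0.47 log units; beyond the scatter) now gives an at least 3.8-fold higher number from compound 2 to compound 3 (0.58 log units; beyond the scatter), so in this assay its direction reverses at this position, para to a large group and ortho to a butoxy group. The result for compound 3 is a limit of the assay and not a number, so the step has a lower bound but no known full size: the limit of > 100000 nM in this assay, at which 1 of the 3 values shown sits.

Together, the two steps show that the effect of adding a butoxy group cannot be carried over from one place on the aromatic ring to another, or from a ring with no butoxy group to one that already has one.

The compounds shown leave open whether the reversal depends on this position itself or on the presence of the earlier butoxy group, a question that a compound with a single butoxy group para to the large group could help to answer. From the compounds shown here alone, it is also open whether a methoxy group, a hydroxyl group or an amine in this place, ortho to the butoxy group, would raise the number as well, or would instead keep it near that of compound 2.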